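This account rests on a few compounds, and the source may have more. Where it says the series, first, only, none or still open, it means among the compounds named here.

Values in an ADME assay on MT4 cells (Homo sapiens) for cytotoxicity, read by MTT assay, with a stated time of 4 days; on this read-out higher numbers stand for lower toxicity in this test and lower numbers for higher toxicity in this test:
- Compound 1 `Cc1c(Cc2c(F)cccc2F)nc(N2CCCCCC2)[nH]c1=O`: > 75000 nM (a limit)
- Compound 2 `Cc1c(C(C)c2c(F)cccc2F)nc(N2CCCC(C)C2)[nH]c1=O`: > 72000 nM (a limit)
- Compound 3 `Cc1c(C(C)c2c(F)cccc2F)nc(N2CCC(C)CC2)[nH]c1=O`: 54000 nM

Compound 3 is the only one of the set with a true number, 54000 nM. The other two entries are limits of this assay, so no ranking among the three can be drawn.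

Compound 4 `Cc1c(C(C)c2c(F)cccc2F)nc(N2CCCCCC2)[nH]c1=O` has not yet been measured. It keeps everything in compound 3 except one group: azepan-1-yl in place of 4-methylpiperidin-1-yl on an aromatic carbon, between two ring nitrogen atoms (azepan-1-yl in place of 4-methylpiperidin-1-yl on an aromatic carbon).

For the measured compounds named here, the only measured step at this place is an at least 1.3-fold lower number from compound 2 to compound 3 (0.12 log units; that floor lies within the scatter). It exchanges 3-methylpiperidin-1-yl for 4-methylpiperidin-1-yl, and its floor lies within the scatter. Compound 1, which also carries azepan-1-yl, stands at the limit > 75000 nM.

Going by the values given here, with a step that small and that limit as the only guides, no change beyond the scatter is expected, and a limit rather than a number is a likely report. The expected change is a 1.1-fold higher number from compound 3 to compound 4 (0.06 log units; within the scatter).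

For compound 4 the estimate is 62000 nM, with an expected range of 35000 nM to 100000 nM.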

Compound 4, half-maximal cytotoxic concentration: > 72000 nM
Compound 4: only a limit was reported; the forecaster's own chance of this, stated with the estimate: 60%; middle value at least 1.1-fold (0.06 log units) from the limit.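

In this assay, exchanging 4-methylpiperidin-1-yl for azepan-1-yl on the aromatic carbon between two ring nitrogen atoms gives an at least 1.3-fold higher number from compound 3 to compound 4 (0.12 log units; that floor lies within the scatter), so this same-sized ring exchange on the core of compound 3 shows no change beyond the scatter. Compound 4 gives > 72000 nM, which is a limit, and it shows that azepan-1-yl can also sit at this place alongside the methyl on the saturated chain carbon without a true number being reported. The steps to compound 4 from compound 2 and from compound 1 cannot be read, and the set remains dominated by limits: the limit of > 72000 nM in this assay, at which 2 of the 4 values shown sit.

How far the true values of compound 1, compound 2 and compound 4 lie past their limits stays open, so no order among these ring amines can be given. Also open, going by these compounds, is whether morpholin-4-yl or piperazin-1-yl at this place, in place of azepan-1-yl, would move the number in this assay beyond the scatter.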